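Aryl variation at the shared core and SR cell growth inhibition

This account rests on a few compounds, and the source may have more. Where it says the series, first, only, none or still open, it means among the compounds named here.

Compound 1 `c1cn2cc(-c3ccsc3)nc(-c3ccc4ncn(C5CCCCC5)c4c3)c2n1`: 14.3%
Compound 2 `Brc1ccc(-c2cn3ccnc3c(-c3ccc4ncn(C5CCCCC5)c4c3)n2)cc1`: 60.7%
Compound 3 `c1csc(-c2cn3ccnc3c(-c3ccc4ncn(C5CCCCC5)c4c3)n2)c1`: 27.2%

In a functional assay on SR cells (Homo sapiens) for inhibition, read by sulforhodamine B assay, with a stated time of 48 h, tested at 10 uM (a higher number here means more inhibition at the concentration tested (going by the name of the read-out), a lower number less inhibition), compound 3 stands second highest of the three measured compounds. Its nearest neighbour is compound 1, which lies lower a number 12.9 percentage points higher from compound 1 to compound 3 (beyond the scatter), while compound 2 lies well above it a number 33.5 percentage points lower from compound 2 to compound 3 (beyond the scatter). Compound 4 `FC(F)(F)c1cccc(-c2cn3ccnc3c(-c3ccc4ncn(C5CCCCC5)c4c3)n2)c1` differs from compound 3 by one change (3-(trifluoromethyl)phenyl in place of thiophen-2-yl on an aromatic carbon). Going by the values given here, the step that bears on this is the one between compound 2 and compound 3, where a six-membered aromatic ring of carbon only with a large group gave a large drop when replaced by thiophen-2-yl a number 33.5 percentage points lower from compound 2 to compound 3 (beyond the scatter). Reversing that kind of change, a large rise is expected for compound 4 a number 22.8 percentage points higher from compound 3 to compound 4 (beyond the scatter). Compound 4 is therefore estimated at 50%, within a range of 25% to 75%.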

Compound 4, a percentage reported as inhibition, at one concentration (the size of the read-out at that concentration, not a potency): 15.6%
The estimate for compound 4 lay 34.4 percentage points above the measured number; the measured number lies below the stated range.
By their numbers in this assay, from the lowest: compounds 1 and 4 (each within the scatter of the next); then compound 3; then compound 2.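

Moving to 3-(trifluoromethyl)phenyl at this position in this assay gives a number 45.1 percentage points lower from compound 2 to compound 4 (beyond the scatter) and does not recover the number of compound 2, so a six-membered aromatic ring of carbon only is not enough to give high inhibition here. The same group gives a number 11.6 percentage points lower from compound 3 to compound 4 (beyond the scatter) and so also falls short of thiophen-2-yl, while a number 1.3 percentage points higher from compound 1 to compound 4 (within the scatter) leaves it level with thiophen-3-yl. No measurement given here accounts for these steps.

The compounds shown leave open whether the number of compound 2 depends on the bromine or on where it sits on the phenyl ring. On these data alone, how a phenyl ring carrying an amine or a carboxylic acid would fare at this position also remains open.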